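Spiro core series: piperazine amide to 3-hydroxypiperidine amide

A few compounds are considered here, and "the series" means these few. Any claim that something is new, unique, unknown or untested is made for them only; others in the source may bear on it.

Measured so far:
- compound 1 `CC(C)(C)c1ccc(C(=O)N2CCC3(CC2)C(=O)N(CC(=O)N2CCNCC2)CN3c2ccccc2)cc1`: 22000 nM
- compound 2 `CCOC(=O)C1CCN(C(=O)CN2CN(c3ccccc3)C3(CCN(C(=O)c4ccc(C5CCCCC5)cc4)CC3)C2=O)CC1`: 900 nM

In an assay on HEK293 cells for displacement of a labelled ligand from NPC1-like intracellular cholesterol transporter 1 (Homo sapiens) (a lower number here means a stronger inhibitor, a higher number a weaker inhibitor), compound 1 gives 22000 nM and stands at the highest of the two numbers. Compound 2 gives 900 nM in this assay; the two values show compound 2 far below compound 1, beyond the scatter, but compound 2 differs from compound 1 in more than one place, so no single step can be read from the pair.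

Compound 3 `CC(C)(C)c1ccc(C(=O)N2CCC3(CC2)C(=O)N(CC(=O)N2CCCC(O)C2)CN3c2ccccc2)cc1` is not yet measured. It differs from compound 1 in one place: 3-hydroxypiperidin-1-yl in place of piperazin-1-yl on a carbonyl carbon. The shared core and the aryl amide are unchanged.

Within the data shown here, no measured step covers this change. Compound 2 is the only other point, and its value shows that a neutral six-membered ring amide at this position is compatible with a lower number, though its aryl group also differs. A modest move toward lower numbers is therefore expected for compound 3, roughly a 2.8-fold lower number from compound 1 to compound 3 (0.44 log units; beyond the scatter) in this assay, uncertain in size. Compound 3 is estimated at 8000 nM with a range from 2500 nM to 25000 nM.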

Compound 3, half-maximal inhibitory concentration: 12200 nM
Compound 3: middle estimate off by 1.5-fold (0.18 log units), on the low side, within the range that was stated.
By their numbers in this assay, from the lowest: compound 2; then compounds 3 and 1 (each within the scatter of the next).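

In this assay, 3-hydroxypiperidin-1-yl in place of piperazin-1-yl on a carbonyl carbon gives a 1.8-fold lower number from compound 1 to compound 3 (0.26 log units; within the scatter), with the aryl amide and the shared core held constant. Among these compounds, this is the first reading of this position on its own, and it shows that this swap leaves compound 1 and compound 3 indistinguishable in this assay. No data at hand bear on the result or offer a reason for it.

Going by these compounds, compound 2 differs from compound 3 in more than one place, so no step can be read from that pair, and how much of the value of compound 2 (900 nM) belongs to its ring amide and how much to its aryl group remains open. Also open, on these data alone, is whether a morpholine or a carboxylic acid on the ring at this carbonyl carbon would give a step beyond the scatter.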